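The source may report more compounds than this note shows. Statements on the series, on what has been measured and on what is new or still open speak of the compounds shown alone.

In a functional assay on HeLa cells (Homo sapiens) for inhibition, read by MTT assay, with a stated time of 72 h (on this read-out higher numbers stand for weaker inhibition and lower numbers for stronger inhibition), compound 3, `COc1cc(NC(C)CCCNC(=O)NNC(=O)Nc2ccc(F)cc2)c2ncccc2c1`, gives only a limit of the assay, >= 250000 nM, and not a number. Among the three measured compounds it sits at the weak end: compound 1, `COc1cc(NC(C)CCCNC(=O)Nc2ccc(O)cc2)c2ncccc2c1`, gives 70000 nM, and compound 2, `COc1cc(NC(C)CCCNC(=O)NNC(=O)Nc2cccc(Cl)c2)c2ncccc2c1`, gives 44000 nM. Compound 4, `COc1cc(NC(C)CCCNC(=O)Nc2cccc(O)c2)c2ncccc2c1`, differs from compound 3 by 3-hydroxyphenyl in place of ((4-fluorophenyl)carbamoyl)amino on an amide-type nitrogen. The closest guide is the step from compound 1 to compound 3, where replacing 4-hydroxyphenyl by the ((4-fluorophenyl)carbamoyl)amino arm gave an at least 3.5-fold higher number from compound 1 to compound 3 (0.55 log units; beyond the scatter); the step from compound 2 to compound 3 gave an at least 5.6-fold higher number from compound 2 to compound 3 (0.75 log units; beyond the scatter), while the step from compound 1 to compound 2 gave a 1.6-fold lower number from compound 1 to compound 2 (0.20 log units; within the scatter). Compound 4 returns to a hydroxyphenyl directly on the amide-type nitrogen, as in compound 1, so the reverse of the step from compound 1 to compound 3 is expected: a modest drop in the number, an at least 3.1-fold lower number from compound 3 to compound 4 (0.49 log units; beyond the scatter). The estimate for compound 4 is therefore 80000 nM, with a range from 25000 nM to 250000 nM.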

Compound 4, half-maximal inhibitory concentration: 48000 nM
Compound 4: the middle estimate sits 1.7-fold (0.22 log units) above what was measured, and the stated range covers the measured number.
By their numbers in this assay, from the lowest: compounds 2, 4 and 1 (each within the scatter of the next). At a limit, above all of these: compound 3.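

In this assay, putting 3-hydroxyphenyl in place of 4-hydroxyphenyl on the amide-type nitrogen gives a 1.5-fold lower number from compound 1 to compound 4 (0.16 log units; within the scatter), so the two hydroxyphenyl groups cannot be told apart here. Compound 4 also stays level with the ((3-chlorophenyl)carbamoyl)amino arm, with a 1.1-fold higher number from compound 2 to compound 4 (0.04 log units; within the scatter), so a directly attached hydroxyphenyl does as well as that much larger arm. Only the ((4-fluorophenyl)carbamoyl)amino arm stands apart, with an at least 5.2-fold lower number from compound 3 to compound 4 (0.71 log units; beyond the scatter), and the true size of this step stays unknown, for compound 3 gives a limit and not a number: the limit of >= 250000 nM in this assay, at which 1 of the 4 values shown sits.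

As far as these compounds go, what a plain phenyl, or a phenyl carrying an amine or a carboxylic acid, would give on this nitrogen stays open. Compound 2 and compound 3 differ in both the halogen and its place on the ring, so which of the two matters is also unresolved.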